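The source may hold more compounds than are shown below. What is called first, only, known or untested is meant among the compounds shown, and "the series" means these compounds.

Compound 1, `O=S(=O)(c1cccc(F)c1)c1n[nH]c2cccc(N3CCNCC3)c12`: in an assay on HeLa cells for displacement of a labelled ligand from 5-hydroxytryptamine receptor 6 (Homo sapiens) (a lower number here means a stronger inhibitor, a higher number a weaker inhibitor), compound 1 gives 134 nM.
Compound 2, `O=S(=O)(c1ccc(Cl)cc1)c1n[nH]c2cccc(N3CCNCC3)c12`: in this assay compound 2 gives 125 nM.
Compound 3, `Cc1ccc(S(=O)(=O)c2n[nH]c3cccc(N4CCNCC4)c23)cc1`: in this assay compound 3 gives 134 nM.

All three share one core and differ only in the six-membered ring attached to the sulfonyl sulfur. Compound 3 stands level with compound 1, the two together holding the highest numbers of the three, and its furthest neighbour is compound 2, separated by a 1.1-fold higher number from compound 2 to compound 3 (0.03 log units; within the scatter). Compound 4, `COc1ccc(S(=O)(=O)c2n[nH]c3cccc(N4CCNCC4)c23)cc1`, has not yet been measured. It differs from compound 3 by methoxy in place of methyl on an aromatic carbon. The measured steps that bear on this are the earlier swaps on the same ring: a 1.1-fold higher number from compound 2 to compound 3 (0.03 log units; within the scatter), which changed the group at the same place, and a 1.1-fold lower number from compound 1 to compound 2 (0.03 log units; within the scatter) and no change at the digits printed from compound 1 to compound 3 (within the scatter), which moved a group between positions. None of these reached beyond the scatter. The expected step is therefore a 1.0-fold lower number from compound 3 to compound 4 (0.01 log units; within the scatter), no change beyond the scatter in this assay. Compound 4 is expected to give 130 nM, with a range from 60 nM to 280 nM.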

Compound 4, inhibition constant: 88 nM
Estimate against measurement, compound 4: 1.5-fold (0.17 log units) above; the measured number falls inside the stated range.
By their numbers in this assay, from the lowest: compounds 4, 2, 1 and 3 (each within the scatter of the next).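

Replacing methyl with methoxy, para to a large group, brings in an oxygen and a hydrogen-bond acceptor, and in this assay the result is a 1.5-fold lower number from compound 3 to compound 4 (0.18 log units; within the scatter). Set against the other two compounds, the picture is the same, with a 1.4-fold lower number from compound 2 to compound 4 (0.15 log units; within the scatter) and also a 1.5-fold lower number from compound 1 to compound 4 (0.18 log units; within the scatter). So this place on the ring now holds a group with an oxygen, as well as chloro and methyl, with no step beyond the scatter, and nothing available here explains the small differences in these numbers.

Every group shown here is small and uncharged, so it remains open whether an amine, a carboxylic acid or a longer chain such as butoxy at this place would give a step beyond the scatter. A second substituent on the same ring is also untested by the compounds shown.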